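The step from compound 3 to compound 4

The source may report more compounds than this note shows. Statements on the series, on what has been measured and on what is new or still open speak of the compounds shown alone.

In a physicochemical assay for lipophilicity, at pH 7.4 (on this read-out lower numbers stand for lower lipophilicity and higher numbers for higher lipophilicity), compound 3 `O=C(Nc1ccc2[nH]ncc2c1)[C@H]1CCCN1C(=O)C1(c2cccc(Cl)c2)CCCC1` gives 5.4, the second highest of three numbers, while compound 1 `COc1ccc(NC(=O)[C@H]2CCCN2C(=O)C2(c3cccc(Cl)c3)CCCC2)nc1` gives 6.8 and compound 2 `O=C(Nc1ccc2[nH]c(=O)[nH]c2c1)[C@H]1CCCN1C(=O)C1(c2cccc(Cl)c2)CCCC1` gives 4.4. Compound 4 `O=C(Nc1ccc2[nH]nnc2c1)[C@H]1CCCN1C(=O)C1(c2cccc(Cl)c2)CCCC1` changes one group of compound 3: a group of 9 heavy atoms (6 carbon, 3 nitrogen; one five-membered aromatic ring with 3 hetero atoms, one six-membered aromatic ring of carbon only) in place of a group of 9 heavy atoms (7 carbon, 2 nitrogen; one five-membered aromatic ring with 2 hetero atoms, one six-membered aromatic ring of carbon only), on an amide-type nitrogen. The closest guide is the modest a number 1.00 log units higher from compound 2 to compound 3 (beyond the scatter), since both of those groups hold a five-membered and a six-membered aromatic ring. The large a number 2.40 log units lower from compound 1 to compound 2 (beyond the scatter) and a number 1.40 log units lower from compound 1 to compound 3 (beyond the scatter) start from a group with a single ring, so they bear on this change less directly. Among the compounds with values here, no measured step makes this exact change, but a modest move toward compound 2 is expected, a number 0.60 log units lower from compound 3 to compound 4 (beyond the scatter). Compound 4 is estimated at 4.8, with an expected range of 4.2 to 5.4.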

Compound 4, distribution coefficient: 5.2
For compound 4 the middle estimate is 0.40 log units below the measured one; low and high end bracket the measured number.
By their numbers in this assay, from the lowest: compound 2; then compounds 4 and 3 (each within the scatter of the next); then compound 1.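

In this assay the extra hetero atom in the five-membered ring gives a number 0.20 log units lower from compound 3 to compound 4 (within the scatter) and so leaves no measurable mark at this amide-type nitrogen. The new group still reads apart from the other two groups, with a number 0.80 log units higher from compound 2 to compound 4 (beyond the scatter) and with a number 1.60 log units lower from compound 1 to compound 4 (beyond the scatter) as well. No measurement shown here offers an explanation for these numbers. Going by these compounds, how a two-ring group carrying a carboxylic acid or an amine would read at this nitrogen stays open.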